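Moving a Hydroxyl Group on a Shared Core

A few compounds are considered here, and "the series" means these few. Any claim that something is new, unique, unknown or untested is made for them only; others in the source may bear on it.

Compound 1, `Oc1cccc(-c2cc(-c3cccs3)cc(-c3ccccc3O)n2)c1`: in a functional assay on T47D cells (Homo sapiens) for cytotoxicity, read by CCK-8 assay (a lower number here means a stronger inhibitor, a higher number a weaker inhibitor), compound 1 gives only a limit, > 50000 nM.
Compound 2, `Oc1cccc(-c2cc(-c3ccsc3)cc(-c3ccccc3O)n2)c1`: in this assay compound 2 gives only a limit, > 50000 nM.
Compound 3, `Oc1ccccc1-c1cc(-c2ccco2)cc(-c2ccccc2O)n1`: in this assay compound 3 gives only a limit, > 50000 nM.

Compound 3 therefore stands nowhere in particular among the numbers shown: all three measured compounds sit at the same point, as the limit of > 50000 nM in this assay, at which 3 of the 3 values shown sit, records, and none can be called stronger or weaker than another. Within the data shown here, the one measured step, a step that the two limits leave unreadable from compound 1 to compound 2, is unreadable because the limit of > 50000 nM in this assay, at which 3 of the 3 values shown sit, hides both ends of it.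

Compound 4, `Oc1cccc(-c2cc(-c3ccco3)cc(-c3ccccc3O)n2)c1`, differs from compound 3 by 3-hydroxyphenyl in place of 2-hydroxyphenyl on an aromatic carbon. Among the measured compounds shown here, no measured step follows this exact change. Compound 1 already carries a 3-hydroxyphenyl group, and its value is only a limit. The same holds for compound 2. On that basis the expected step that the limit leaves unreadable from compound 3 to compound 4 is none beyond the scatter, with compound 4 expected to remain at the limit rather than to become readable. For compound 4 the expected value in this assay is 80000 nM, with a range from 30000 nM to 300000 nM.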

Compound 4, half-maximal inhibitory concentration: 820 nM
Estimate against measurement, compound 4: 98-fold (1.99 log units) above, outside the stated range (below it).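

With furan-2-yl held constant, 3-hydroxyphenyl in place of 2-hydroxyphenyl next to the ring nitrogen gives an at least 60-fold lower number from compound 3 to compound 4 (1.78 log units; beyond the scatter) in this assay, so the placement of one hydroxyl on this group can decide whether a readable value appears at all. The 3-hydroxyphenyl group is not enough on its own, as the ring at the other position also counts: furan-2-yl in place of thiophen-3-yl gives an at least 60-fold lower number from compound 2 to compound 4 (1.78 log units; beyond the scatter), and furan-2-yl in place of thiophen-2-yl gives an at least 60-fold lower number from compound 1 to compound 4 (1.78 log units; beyond the scatter). Each of these steps is a minimum rather than an exact size, because one end of it is a limit: the limit of > 50000 nM in this assay, at which 3 of the 4 values shown sit.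

Whether the hydroxyl itself is needed stays open, as the compounds shown do not include a methoxy group or an amine in its place. Also open, on these data alone, is what 3-hydroxyphenyl would do in place of the remaining 2-hydroxyphenyl group.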